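The source may hold more compounds than are shown below. What is called first, only, known or untested is meant among the compounds shown, and "the series" means these compounds.

Measured in a functional assay on A-375 cells (Homo sapiens) for cytotoxicity, read by MTT assay; a lower number here means a stronger inhibitor, a higher number a weaker inhibitor:
- compound 1 `COc1ccc(/C=C/C(=O)c2ccc(OC)c3c2OC(C)(C)C=C3)cc1O` gives 800 nM
- compound 2 `CCCCC(=O)Oc1cc(/C=C/C(=O)c2ccc(OC)c3c2OC(C)(C)C=C3)ccc1OC` gives 220 nM
- compound 3 `COc1ccc(/C=C/C(=O)c2ccc(OC)c3c2OC(C)(C)C=C3)cc1OC(=O)c1ccc(Br)cc1` gives 420 nM

Compound 3 cannot be told apart from the other two, as the data show (a 1.9-fold lower number from compound 1 to compound 3 (0.28 log units; within the scatter); a 1.9-fold higher number from compound 2 to compound 3 (0.28 log units; within the scatter)). Going by the values given here, only one real step appears (a 3.6-fold lower number from compound 1 to compound 2 (0.56 log units; beyond the scatter)).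

Compound 4 `COc1ccc(/C=C/C(=O)c2ccc(OC)c3c2OC(C)(C)C=C3)cc1OS(=O)(=O)Cc1ccccc1` has benzylsulfonyl in place of (4-bromophenyl)carbonyl on an oxygen on an aromatic ring. Among the compounds with values here, no measured compound carries a sulfonyl group there, so the guide is loose. Within the data shown here, the closest precedent is the swap of one carbonyl group for another (a 1.9-fold higher number from compound 2 to compound 3 (0.28 log units; within the scatter)). The expected change is therefore none beyond the scatter (a 1.2-fold lower number from compound 3 to compound 4 (0.08 log units; within the scatter)). The estimated value for compound 4 is 350 nM (expected range 140 nM to 900 nM).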

Compound 4, half-maximal inhibitory concentration: > 10000 nM
Compound 4 was reported as a limit (the forecaster's own chance of this, stated with the estimate: 2%); at least 28-fold (1.45 log units) between middle value and limit.
By their numbers in this assay, from the lowest: compounds 2, 3 and 1 (each within the scatter of the next, the first and the last beyond it). At a limit, above all of these: compound 4.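

Compound 4 is reported only as a limit, > 10000 nM, in this assay: the limit of > 10000 nM in this assay, at which 1 of the 4 values shown sits.

Swapping one carbonyl group for another on this oxygen stayed within the scatter, but benzylsulfonyl in place of either carbonyl group gives large steps (an at least 23-fold higher number from compound 3 to compound 4 (1.37 log units; beyond the scatter); an at least 45-fold higher number from compound 2 to compound 4 (1.65 log units; beyond the scatter)). It also compares badly with plain hydrogen on the same oxygen (an at least 12-fold higher number from compound 1 to compound 4 (1.09 log units; beyond the scatter)), so this position does not accept every group.

From the compounds shown here alone, whether the sulfonyl link or the benzyl part carries this loss remains open. A methylsulfonyl group or a benzylcarbonyl group on the same oxygen would separate the two.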